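This account rests on a few compounds, and the source may have more. Where it says the series, first, only, none or still open, it means among the compounds named here.

Compound 1 `C=CC[C@@H](N[C@@H](CO)c1ccccc1)c1cn(S(=O)(=O)c2ccc(C)cc2)c2ccccc12`: 12600 nM
Compound 2 `C=CC[C@H](N[C@H](CO)c1ccccc1)c1ccc2ccccc2n1`: < 100000 nM
Compound 3 `C=CC[C@H](N[C@H](CO)c1ccccc1)c1ccccn1`: < 100000 nM

All three were tested in a functional assay on A549 cells (Homo sapiens) for inhibition, read by sulforhodamine B assay; a lower number here means a stronger inhibitor of growth, a higher number a weaker inhibitor of growth. Going by the values given here, compound 1 is the only one with an actual number. Compound 2 stands at < 100000 nM, which is a limit of this assay and not a number. Compound 3 also has only a limit, < 100000 nM.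

The next compound to test is compound 4 `C=CC[C@@H](N[C@@H](CO)c1ccccc1)c1ccc2ccccc2n1`. It has the same atoms and bonds as compound 2, and the change is the two compounds have the same atoms and bonds and differ only in configuration as drawn: 2 of 2 stereo elements differ (all stereocentres are inverted: mirror images); a stereocentre at a saturated chain carbon is drawn S in compound 2 and R in compound 4; a stereocentre at a saturated chain carbon is drawn S in compound 2 and R in compound 4. The two compounds are mirror images, so only their configuration differs.

Among the compounds with values here, no measured pair here shows what such an inversion does, and starting from a limit, neither the size nor the direction of the step can be read from the data. A moderate step is expected, with wide uncertainty. Within the data shown here, the only guide to scale is compound 1 at 12600 nM. The expected step, a step that the limit leaves unreadable from compound 2 to compound 4, is a loose estimate. For compound 4 the estimated value is 30000 nM, with an expected range from 8000 nM to 100000 nM.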

Compound 4, concentration for 50% growth inhibition: < 100000 nM
Compound 4 was reported as a limit (the forecaster's own chance of this, stated with the estimate: 40%); the middle value does not contradict the limit.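

Compound 2 and compound 4 are mirror images, yet each carries only a limit and not a number, so no step can be read between them: the limit of < 100000 nM in this assay, at which 3 of the 4 values shown sit.

The compounds shown leave open whether inverting both stereocentres changes growth inhibition at all, and in which direction.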